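Methoxy in Place of Chloro: From Compound 2 to Compound 4

The source may hold more compounds than are shown below. What is called first, only, known or untested is meant among the compounds shown, and "the series" means these compounds.

Measured compounds:
compound 1 `CCOc1ccc(COc2c(OC)cc(/C=C/C(=O)OCC(=O)Nc3ccccc3)cc2OC)cc1`: > 200000 nM (a limit of the assay)
compound 2 `O=C(COC(=O)/C=C/c1ccc(O)c(O)c1)Nc1ccc(Cl)cc1`: 108000 nM
compound 3 `COc1ccc(NC(=O)COC(=O)/C=C/c2cc(OC)c(OCc3ccccc3)c(OC)c2)cc1`: > 200000 nM (a limit of the assay)

Among the measured compounds shown here, in a functional assay on LS174T cells (Homo sapiens) for cytotoxicity, read by MTT assay, with a stated time of 72 h (on this read-out lower numbers stand for stronger inhibition and higher numbers for weaker inhibition), compound 2 stands as the only compound with a measured number. Compound 1 reaches only a limit, namely (the limit of > 200000 nM in this assay, at which 2 of the 3 values shown sit). For the measured compounds named here, compound 3 likewise reaches only that limit and no number. Compound 2 therefore cannot be ranked against the other two beyond the statement that it alone gives a number and they do not.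

Compound 4 `COc1ccc(NC(=O)COC(=O)/C=C/c2ccc(O)c(O)c2)cc1` differs from compound 2 by methoxy in place of chloro on an aromatic carbon. Going by the values given here, no step between measured compounds covers this change. The expected step of a 1.4-fold higher number from compound 2 to compound 4 (0.14 log units; within the scatter) is small and lies within the usual scatter, if anything leaning toward weaker inhibition. Compound 3 carries the same methoxyphenyl amide and gives > 200000 nM, a limit. Compound 4 is thus expected to fall at about 150000 nM in this assay, with a range from 70000 nM to 300000 nM, and a fair chance that only a limit is reported.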

Compound 4, half-maximal inhibitory concentration: 124000 nM
For compound 4 the middle estimate is 1.2-fold (0.08 log units) above the measured one, within the range that was stated.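

In this assay, among the compounds shown here, the change from 4-chlorophenyl to 4-methoxyphenyl gives the only step between measured compounds that differ in one place: a 1.1-fold higher number from compound 2 to compound 4 (0.06 log units; within the scatter). That step lies within the scatter, so on this aromatic carbon, para to a large group, chloro and methoxy cannot be told apart on this read-out. Compound 2 and compound 4 both give numbers, while the remaining compounds shown give only a limit and no step links them to either: the limit of > 200000 nM in this assay, at which 2 of the 4 values shown sit.

The compounds shown leave open whether another group at this position, such as an amine or a carboxylic acid, would move the number beyond the scatter. They also leave open what the hydroxy groups of compound 2 and compound 4 contribute, as no pair shown differs in those groups alone.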